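This account rests on a few compounds, and the source may have more. Where it says the series, first, only, none or still open, it means among the compounds named here.

Measured compounds:
- compound 1, `Cc1ccc(-n2cc(CCCCO)nn2)cc1Nc1nccc(-c2cccnc2)n1`: in a functional assay on K562 cells (Homo sapiens) for inhibition, read by MTT assay, with a stated time of 72 h (a lower number here means a stronger inhibitor, a higher number a weaker inhibitor), compound 1 gives 11200 nM
- compound 2, `Cc1ccc(-c2nnc(-c3ccc(C)c(C(F)(F)F)c3)o2)cc1Nc1nccc(-c2cccnc2)n1`: compound 2 gives > 30000 nM in this assay

Compound 2 stands at the limit of this assay: its value of > 30000 nM is a limit, not a number, as the limit of > 30000 nM in this assay, at which 1 of the 2 values shown sits, records. Compound 1 is the only one of the two with a measured number, 11200 nM. Compound 3, `Cc1nnc(-c2ccc(C)c(Nc3nccc(-c4cccnc4)n3)c2)o1`, differs from compound 2 by methyl in place of 4-methyl-3-(trifluoromethyl)phenyl on an aromatic carbon. Among the measured compounds shown here, no measured pair covers a change of this kind, so nothing sets its size or direction. With compound 2 known only as a limit, the step of an at least 1.2-fold lower number from compound 2 to compound 3 (0.07 log units; that floor lies within the scatter) is expected to be modest and could as well be none beyond the scatter. Compound 3 is expected to give about 25000 nM, with a range from 6000 nM to 80000 nM.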

Compound 3, half-maximal inhibitory concentration: > 30000 nM
Compound 3 gave a limit, no number; the forecaster's own chance of this, stated with the estimate: 45%; middle value at least 1.2-fold (0.07 log units) away from the limit.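

In this assay compound 3 gives > 30000 nM, which is a limit and not a number. Replacing 4-methyl-3-(trifluoromethyl)phenyl with methyl on the five-membered aromatic ring with 2 nitrogen and 1 oxygen therefore does not bring this series off the limit, and the two limits leave the step between compound 2 and compound 3 unreadable. The one readable comparison is an at least 2.6-fold higher number from compound 1 to compound 3 (0.42 log units; beyond the scatter), with 5-methyl-1,3,4-oxadiazol-2-yl in place of 4-(4-hydroxybutyl)-1H-1,2,3-triazol-1-yl, and the readings now gather at one end of the assay: the limit of > 30000 nM in this assay, at which 2 of the 3 values shown sit.

From the compounds shown here alone, that step changes the ring and its substituent together, so their separate shares remain open. Also open, going by these compounds, is whether an amine or a carboxylic acid carried on a longer chain at this position would give a measurable number.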